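The source may hold more compounds than are shown below. What is called first, only, known or untested is meant among the compounds shown, and "the series" means these compounds.

Measured so far:
compound 1 `O=COC1(C(=O)Nc2ccc([N+](=O)[O-])cc2)CCCCC1` — 34.1 nM
compound 2 `CCC(=O)OC1(C(=O)Nc2ccc([N+](=O)[O-])cc2)CCCCC1` — 21.5 nM

Among the compounds with values here, compound 2 has the lower of the two numbers in a functional assay on HepG2 cells (Homo sapiens) for inhibition, read by MTT assay, with a stated time of 72 h (on this read-out higher numbers stand for weaker inhibition and lower numbers for stronger inhibition), compound 1 being its only neighbour; the step of a 1.6-fold lower number from compound 1 to compound 2 (0.20 log units; within the scatter) lies within the scatter, so no order between the two is claimed. Compound 3 `O=C(Nc1ccc([N+](=O)[O-])cc1)C1(O)CCCCC1` is not yet measured. It differs from compound 2 by hydrogen in place of propanoyl on an oxygen on a saturated carbon; propanoyloxy becomes hydroxy. Within the data shown here, the single measured step, a 1.6-fold lower number from compound 1 to compound 2 (0.20 log units; within the scatter), changed only the size of the acyl group, not its presence, and was within the scatter, so it bears on this change only indirectly. For compound 3 the estimated step is a 1.4-fold higher number from compound 2 to compound 3 (0.14 log units; within the scatter), with no clear direction expected. Compound 3 is expected to give about 30 nM in this assay, between 10 nM and 100 nM.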

Compound 3, half-maximal inhibitory concentration: 648 nM
Compound 3: the middle estimate sits 22-fold (1.33 log units) below what was measured; measured number outside the range, above it.
By their numbers in this assay, from the lowest: compounds 2 and 1 (each within the scatter of the next); then compound 3.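

In this assay the oxygen on the saturated carbon proves sensitive to loss of its acyl group, with propanoyloxy to hydroxy giving a large step (a 30-fold higher number from compound 2 to compound 3 (1.48 log units; beyond the scatter)) and loss of formyl giving another (a 19-fold higher number from compound 1 to compound 3 (1.28 log units; beyond the scatter)). Formyl and propanoyl remain within the scatter of each other, so among these compounds the presence of an acyl group separates the values, not its size. As far as these compounds go, whether a methyl ether, an amine or a longer acyl chain such as butanoyl at this place would match the acylated compounds stays open. Nothing available explains the large steps.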